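A few compounds are considered here, and "the series" means these few. Any claim that something is new, unique, unknown or untested is made for them only; others in the source may bear on it.

Series notes. In a functional assay on HepG2 cells (Homo sapiens) for cytotoxicity, with a stated time of 24 h (a higher number here means a weaker inhibitor, a lower number a stronger inhibitor), compound 2, `O=C(NNC(=O)c1cc(I)cc(I)c1O)c1ccccc1`, gives 98000 nM, the only number shown. Compound 1, `O=C(N/N=C/c1cc(I)c(O)c(I)c1)c1ccc(Cl)cc1`, reaches only the limit > 100000 nM in this assay, the case described as the limit of > 100000 nM in this assay, at which 1 of the 2 values shown sits. Compound 3, `COc1ccc(C(=O)NNC(=O)c2cc(I)cc(I)c2O)cc1`, is not yet measured. It differs from compound 2 by methoxy in place of hydrogen on an aromatic carbon. Within the data shown here, no measured pair isolates such a change, so no step beyond the scatter is expected in this assay, in either direction. Compound 3 is estimated at 100000 nM, within 40000 nM to 250000 nM. The expected step of a 1.0-fold higher number from compound 2 to compound 3 (0.01 log units; within the scatter) lies within the scatter.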

Compound 3, half-maximal inhibitory concentration: 132000 nM
For compound 3 the middle estimate is 1.3-fold (0.12 log units) below the measured one; low and high end bracket the measured number.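

In this assay, among these compounds, the only measured pair shows a 1.3-fold higher number from compound 2 to compound 3 (0.13 log units; within the scatter) with methoxy in place of hydrogen on an aromatic carbon, para to a large group. Among the compounds shown here, this place on the ring therefore takes methoxy with no step beyond the scatter, which no earlier compound could show. Compound 1 remains a limit, not a number: the limit of > 100000 nM in this assay, at which 1 of the 3 values shown sits.

From the compounds shown here alone, whether an amine or a carboxylic acid at this place would give a step beyond the scatter stays open. Also open, going by these compounds, is whether a longer chain in place of methoxy would do so.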